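A few compounds are considered here, and "the series" means these few. Any claim that something is new, unique, unknown or untested is made for them only; others in the source may bear on it.

Measured compounds:
Compound 1 `C=C(c1ccc(F)c(F)c1)C1COC(C)(C)OO1` — > 100000 nM
Compound 2 `C=C(c1ccc(OC)c(F)c1)C1COC(C)(C)OO1` — > 100000 nM
Compound 3 `C=C(c1ccc(F)c(F)c1)C1COC2(CCCCC2)OO1` — 28600 nM

In a functional assay on HepG2 cells (Homo sapiens) for inhibition, read by MTT assay, with a stated time of 72 h (on this read-out lower numbers stand for stronger inhibition and higher numbers for weaker inhibition), compound 1 gives > 100000 nM, which is a limit of the assay and not a number. Compound 2 likewise gives only a limit, > 100000 nM. The change between them, (methoxy in place of fluoro on an aromatic carbon), therefore made a step that the two limits leave unreadable from compound 1 to compound 2; its size cannot be read because both values sit at the limit of > 100000 nM in this assay, at which 2 of the 3 values shown sit. Among the measured compounds shown here, compound 3 is the only one with a number: in this assay compound 3 gives 28600 nM. How the core of compound 3 differs from the core of compound 1 is not broken down here.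

Compound 4 `C=C(c1ccc(OC)c(F)c1)C1COC2(CCCCC2)OO1` carries the same change as compound 2: methoxy in place of fluoro on an aromatic carbon. The earlier instance gives no readable size, so compound 4 is expected to stand close to compound 3, with an estimated step of a 1.2-fold higher number from compound 3 to compound 4 (0.09 log units; within the scatter). Compound 4 is thus estimated at 35000 nM, between 10000 nM and 100000 nM.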

Compound 4, half-maximal inhibitory concentration: 13100 nM
For compound 4 the middle estimate is 2.7-fold (0.43 log units) above the measured one; the range from low to high includes it.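

In this assay, methoxy in place of fluoro on an aromatic carbon gave a 2.2-fold lower number from compound 3 to compound 4 (0.34 log units; beyond the scatter). Among the compounds shown here, this is the only readable instance of the change, so it shows the change on one core and does not show that the result carries from one core to another. The same change on the core of compound 1 cannot be read, and the matching pair there offers no size to compare: the limit of > 100000 nM in this assay, at which 2 of the 4 values shown sit.

The compounds shown leave open how an amine, a carboxylic acid or a longer chain at that place would stand on the core of compound 3. They also leave open whether methoxy would give a readable step on any further core.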